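This account rests on a few compounds, and the source may have more. Where it says the series, first, only, none or still open, it means among the compounds named here.

Measured so far:
compound 2 `COc1cc(N)c(Cl)cc1C(=O)CCC1CCN(CCNS(=O)(=O)c2cc(Br)c(N)c(Br)c2)CC1` — 52%
compound 1 `COc1ccc(S(=O)(=O)NCCCN2CCC(CCC(=O)c3cc(Cl)c(N)cc3OC)CC2)cc1` — "not active" (no number reported)

Among the measured compounds shown here, compound 2 holds the only number in an assay on HEK293 cells for displacement of a labelled ligand from 5-hydroxytryptamine receptor 6 (Homo sapiens), with a stated time of 60 min, tested at 0.01 uM, in the presence of a further agent that is not named here; on this read-out higher numbers stand for a stronger effect at the one concentration tested and lower numbers for a weaker effect; compound 1 is given without a number in this assay. For the measured compounds named here, no single-point step between them is counted, since they differ in more than one place.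

Compound 3 `COc1ccc(S(=O)(=O)NCCN2CCC(CCC(=O)c3cc(Cl)c(N)cc3OC)CC2)cc1OC` is not yet measured. It differs from compound 2 in one place, (3,4-dimethoxyphenyl in place of 4-amino-3,5-dibromophenyl on a sulfonyl sulfur). Compound 1, which also carries a methoxylated phenyl on the sulfonyl sulfur, gave "not active" (no number reported), so a fall beyond the scatter is expected, a number 32 percentage points lower from compound 2 to compound 3 (beyond the scatter). Compound 3 is estimated at 20%, within 0% to 45%.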

Compound 3, a percentage reported as inhibition, at one concentration (the size of the read-out at that concentration, not a potency): 3%
Compound 3: the middle estimate sits 17 percentage points above what was measured, and the stated range covers the measured number.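

With the rest of the molecule unchanged, the group on the sulfonyl sulfur decides the read-out in this assay: 3,4-dimethoxyphenyl in place of 4-amino-3,5-dibromophenyl gives a number 49 percentage points lower from compound 2 to compound 3 (beyond the scatter) as a large step. Compound 1 could not show this, since it differs from compound 2 in more than one place. No supporting data bear on this step.

The compounds shown leave open whether the bromines, the amine or the methoxy groups account for the step. A 4-aminophenyl or a 3,5-dibromophenyl on this sulfur would separate them.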